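The source may hold more compounds than are shown below. What is called first, only, known or untested is meant among the compounds shown, and "the series" means these compounds.

Working notes on the series. Compound 1 `CC(=O)Nc1ccn(C2OC(CO[Si](C)(C)C(C)(C)C)C(C#N)C2O[Si](C)(C)C(C)(C)C)c(=O)n1` and compound 2 `N#C[C@@H]1[C@@H](O)[C@H](n2cnc3c(N)ncnc32)O[C@@H]1CO` have been tested in a functional assay on cells (Fibroblast, Mus musculus) for cytotoxicity; on this read-out higher numbers stand for lower toxicity in this test and lower numbers for higher toxicity in this test. For compound 1 the read-out is a limit, > 3.2 ug/mL, as recorded in the limit of > 3.2 ug/mL in this assay, at which 1 of the 2 values shown sits. For compound 2 the read-out is also a limit, > 40 ug/mL, as recorded in the limit of > 40 ug/mL in this assay, at which 1 of the 2 values shown sits. Both entries are limits rather than numbers, so compound 2 cannot be ranked against compound 1 on these data. Compound 3 `N#C[C@H]1[C@@H](O)[C@H](n2cnc3c(N)ncnc32)O[C@@H]1CO` has not yet been measured in this assay. The change from compound 2 to compound 3 is the two compounds have the same atoms and bonds and differ only in configuration as drawn: 1 of 4 stereo elements differ; a stereocentre at a saturated ring carbon is drawn R in compound 2 and S in compound 3. Among the compounds with values here, no step between two measured compounds is available in this set, so the size of this step has to be judged from the change alone. The step from compound 2 to compound 3 is expected to be none beyond the usual scatter, a number no higher from compound 2 to compound 3 (the limit leaves the size open). Compound 3 is therefore estimated at 40 ug/mL, with a range from 20 ug/mL to 80 ug/mL, and most likely again reported only as a limit.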

Compound 3, minimum cytotoxic concentration: > 40 ug/mL
Compound 3 gave a limit, no number; the forecaster's own chance of this, stated with the estimate: 75%; the middle value lies on the limit itself.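

Within the data shown here, compound 2 and compound 3 are both recorded only as limits in this assay, and no step between them can be read. The compounds shown leave open whether the change of configuration at the saturated ring carbon shifts this read-out at all.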